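A few compounds are considered here, and "the series" means these few. Any claim that something is new, unique, unknown or untested is made for them only; others in the source may bear on it.

Compound 2 `CCO/C(O)=C1\C(COCCn2c(C)nc(C)c2C)=NC(C)=C(C(=O)OC)C1c1ccccc1Cl` shares its core with compound 1 `CCO/C(O)=C1\C(COCCn2ccnn2)=NC(C)=C(C(=O)OC)C1c1cccc(Cl)c1Cl` and compound 3 `CCOC(=O)c1cn(CCOCC2=NC(C)=C(C(=O)OC)C(c3ccccc3Cl)/C2=C(\O)OCC)nn1`; the three differ only in the ring carried on a saturated chain carbon, two bonds along the chain from an oxygen on a saturated carbon. In a functional assay (aorta) with Rattus norvegicus as the target (a lower number here means a stronger inhibitor, a higher number a weaker inhibitor), compound 2 gives 5.01 nM. Compound 1 gives 5.01 nM, so these two stand level at the digits shown and together hold the lowest numbers of the three. Compound 3 gives 50.1 nM, the step being a 10-fold higher number from compound 2 to compound 3 (1.00 log units; beyond the scatter).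

Compound 4 `CCO/C(O)=C1\C(COCCn2c(N)cnc2O)=NC(C)=C(C(=O)OC)C1c1ccccc1Cl` is not yet measured in this assay. It differs from compound 2 in one place: 5-amino-2-hydroxy-1H-imidazol-1-yl in place of 2,4,5-trimethyl-1H-imidazol-1-yl on a saturated chain carbon, two bonds along the chain from an oxygen on a saturated carbon. For the measured compounds named here, the only measured step that bears on this is the exchange of the ring at the same place, a 10-fold higher number from compound 2 to compound 3 (1.00 log units; beyond the scatter), which shows that swapping this ring for another five-membered ring can weaken inhibition noticeably. The ring entering in compound 4 is again different from both, so a rise is expected, though a smaller one than in that step is just as plausible. Compound 4 is therefore estimated at 12 nM in this assay, within a range from 4 nM to 40 nM, which amounts to an expected step of a 2.4-fold higher number from compound 2 to compound 4 (0.38 log units; beyond the scatter).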

Compound 4, half-maximal inhibitory concentration: 158 nM
Compound 4: the middle estimate sits 13-fold (1.12 log units) below what was measured; measured number outside the range, above it.
By their numbers in this assay, from the lowest: compounds 1 and 2 (each within the scatter of the next); then compound 3; then compound 4.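

Keeping the five-membered aromatic ring with 2 hetero atoms does not keep the inhibition in this assay: replacing 2,4,5-trimethyl-1H-imidazol-1-yl with 5-amino-2-hydroxy-1H-imidazol-1-yl gives a 32-fold higher number from compound 2 to compound 4 (1.50 log units; beyond the scatter) and marks this as the largest step seen so far at this position. Compound 2 and compound 4 both carry an imidazol-1-yl ring on the saturated chain carbon, so the groups on the ring can shift the number substantially even when the ring itself is the same kind. The result also separates the two weaker compounds, with a 3.2-fold higher number from compound 3 to compound 4 (0.50 log units; beyond the scatter) when 5-amino-2-hydroxy-1H-imidazol-1-yl takes the place of 4-(ethoxycarbonyl)-1H-1,2,3-triazol-1-yl, and no measurement at hand accounts for either step.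

Amino and hydroxy enter together while the methyl groups leave, so the compounds shown cannot say which of these exchanges drives the rise. A plain 1H-imidazol-1-yl ring, or a ring bearing amino alone or hydroxy alone, would help to separate them, while a propyl chain in place of the ethyl chain would test another part of this position.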